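Swapping a ring for a chain at compound 1

A few compounds are considered here, and "the series" means these few. Any claim that something is new, unique, unknown or untested is made for them only; others in the source may bear on it.

Measured compounds:
- compound 1 `CC(C)(C)C(=O)N1Cc2c(NC(=O)C3CCNCC3)n[nH]c2C1(C)C`: 650 nM
- compound 2 `CN1CCC(C(=O)N2Cc3c(NC(=O)c4ccc5ccccc5c4)n[nH]c3C2(C)C)CC1`: 270 nM

In a functional assay on A2780 cells (Homo sapiens) for antiproliferative activity, read by fluorescence, with a stated time of 72 h (a higher number here means a weaker inhibitor, a lower number a stronger inhibitor), compound 1 gives 650 nM and so holds the higher of the two numbers, which makes it the weaker inhibitor of the pair. Compound 2 gives 270 nM, a gap beyond the usual scatter. These two compounds differ in more than one place, so their gap does not isolate any single change.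

Compound 3 `CN(C)CC(=O)Nc1n[nH]c2c1CN(C(=O)C(C)(C)C)C2(C)C` keeps the core of compound 1 and changes one group: (dimethylamino)methyl in place of piperidin-4-yl on a carbonyl carbon. In plain terms, (dimethylamino)methyl stands in place of piperidin-4-yl on a carbonyl carbon, so a ring gives way to an open chain. For the measured compounds named here, no measured step shows what this swap does, which leaves compound 1 at 650 nM as the only anchor and makes any forecast uncertain. A moderate step toward a higher number in this assay is expected, meaning a somewhat weaker inhibitor. The expected change is a 2.3-fold higher number from compound 1 to compound 3 (0.36 log units; beyond the scatter) as an estimate. For compound 3 the estimated value is 1500 nM, with an expected range from 450 nM to 5000 nM in this measurement.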

Compound 3, half-maximal inhibitory concentration: 580 nM
Beside the measured number, compound 3's estimate is 2.6-fold (0.41 log units) above it; measured number inside the range.
By their numbers in this assay, from the lowest: compound 2; then compounds 3 and 1 (each within the scatter of the next).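

In this assay, putting (dimethylamino)methyl in place of piperidin-4-yl on a carbonyl carbon gives a 1.1-fold lower number from compound 1 to compound 3 (0.05 log units; within the scatter), so the two compounds cannot be told apart in this measurement. For the compounds shown here, this is the first direct reading at this spot, and it shows that, on the core of compound 1, the six-membered non-aromatic ring can give way to an open chain with fewer heavy atoms and no hydrogen-bond donor while the number remains within the usual scatter. Nothing measured here accounts for why these two different groups read alike, and this single pair cannot show which of their shared or differing features matters.

Still open, going by these compounds, is how a longer chain, such as 2-(dimethylamino)ethyl, or a chain ending in a carboxylic acid instead of an amine, would read on the same carbonyl carbon. Also open, on these data alone, is whether the same swap would give a similar result on a compound carrying the other groups of compound 2, since a single step on one core cannot be carried over to another.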